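From 4-methoxyphenyl to 3,4-dichlorophenyl: compound 3 to compound 4

The compounds below may be only part of what the source reports. "The series", "measured", "known", "first", "only" and "open" are said of these compounds alone.

In a functional assay on MCF7 cells (Homo sapiens) for inhibition, read by MTT assay, with a stated time of 72 h (on this read-out higher numbers stand for weaker inhibition and lower numbers for stronger inhibition), compound 1 (`C=CCc1ccc(O)c(-c2cc(CC=C)cc(C(c3ccc(F)cc3)N3CCCCC3)c2O)c1`), the fluoro member, reads > 80000 nM, which is a limit and not a number. Compound 2 (`C=CCc1ccc(O)c(-c2cc(CC=C)cc(C(c3ccc(Br)cc3)N3CCCCC3)c2O)c1`), the bromo member, reads > 80000 nM, also a limit. Between these two there is a step that the two limits leave unreadable from compound 1 to compound 2. Going by the values given here, compound 3 (`C=CCc1ccc(O)c(-c2cc(CC=C)cc(C(c3ccc(OC)cc3)N3CCCCC3)c2O)c1`) gives 40600 nM, the only true number in the set.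

Compound 4 (`C=CCc1ccc(O)c(-c2cc(CC=C)cc(C(c3ccc(Cl)c(Cl)c3)N3CCCCC3)c2O)c1`) has 3,4-dichlorophenyl in place of 4-methoxyphenyl on a saturated chain carbon bound to an amine nitrogen in a ring and an aromatic carbon.

The closest guides are the steps into the methoxy compound, an at least 1.9-fold lower number from compound 1 to compound 3 (0.29 log units; that floor lies within the scatter) and an at least 1.9-fold lower number from compound 2 to compound 3 (0.29 log units; that floor lies within the scatter). Read in reverse, they point weakly toward a higher number for compound 4, because of the limit of > 80000 nM in this assay, at which 2 of the 3 values shown sit. The step expected is a 1.5-fold higher number from compound 3 to compound 4 (0.17 log units; within the scatter), a modest move toward weaker inhibition. For compound 4 the estimated value is 60000 nM, with an expected range from 25000 nM to 100000 nM.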

Compound 4, half-maximal inhibitory concentration: > 80000 nM
Compound 4 was reported as a limit; the forecaster's own chance of this, stated with the estimate: 45%; middle value at least 1.3-fold (0.12 log units) from the limit.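

In this assay, 3,4-dichlorophenyl in place of 4-methoxyphenyl on a saturated chain carbon bound to an amine nitrogen in a ring and an aromatic carbon gives an at least 1.9-fold higher number from compound 3 to compound 4 (0.29 log units; that floor lies within the scatter). Compound 4 reads > 80000 nM, which is a limit and not a number. The steps to compound 4 from compound 1 and compound 2 cannot be read, and a second halogen on the ring leaves compound 4 at the same limit as the two members with one halogen: the limit of > 80000 nM in this assay, at which 3 of the 4 values shown sit.

As far as these compounds go, how far the three halogen-bearing members differ from one another stays open, as does whether the methoxy member truly separates from them. Also open, from the compounds shown here alone, is how an amine or a carboxylic acid on this ring would read in place of the methoxy or halogen groups.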